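The source may report more compounds than this note shows. Statements on the series, on what has been measured and on what is new or still open speak of the compounds shown alone.

Compound 1, `Cc1cc(C)c(-c2nc3ccccc3[nH]2)cc1NC(=O)c1ccc(OCc2ccccn2)cc1`: in a physicochemical assay for solubility, at pH 7.4 (on this read-out lower numbers stand for lower solubility and higher numbers for higher solubility), compound 1 gives < 1000 nM, which is a limit of the assay and not a number.
Compound 2, `Cc1cc(C)c(-c2c(C)nn(C)c2C)cc1NC(=O)c1ccc(OCc2ccccn2)cc1`: in this assay compound 2 gives 35000 nM.
Compound 3, `Cc1cc(C)c(-c2cccnc2)cc1NC(=O)c1ccc(OCc2ccccn2)cc1`: in this assay compound 3 gives 9000 nM.

Among the two numbers shown, compound 3 stands lowest; its nearest neighbour is compound 2, and the step of a 3.9-fold lower number from compound 2 to compound 3 (0.59 log units; beyond the scatter) lies beyond the scatter. Compound 1 sits at the limit of < 1000 nM in this assay, at which 1 of the 3 values shown sits, so the step of an at least 9.0-fold higher number from compound 1 to compound 3 (0.95 log units; beyond the scatter) is known only as a bound. Compound 4, `Cc1cc(C)c(-c2ccc(N)cn2)cc1NC(=O)c1ccc(OCc2ccccn2)cc1`, has not yet been measured. It differs from compound 3 in one place: 5-aminopyridin-2-yl in place of pyridin-3-yl on an aromatic carbon. Among the measured compounds shown here, no measured step covers this exact change. The steps of an at least 35-fold higher number from compound 1 to compound 2 (1.54 log units; beyond the scatter), an at least 9.0-fold higher number from compound 1 to compound 3 (0.95 log units; beyond the scatter) and a 3.9-fold lower number from compound 2 to compound 3 (0.59 log units; beyond the scatter) each exchange one heteroaryl for another, and they move the number by modest to large amounts. The entering group keeps a six-membered ring with one hetero atom, so a modest step in this assay, a 1.8-fold higher number from compound 3 to compound 4 (0.25 log units; within the scatter), is expected, in the higher direction. Compound 4 is therefore estimated to give 16000 nM, with a range from 5000 nM to 50000 nM.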

Compound 4, solubility: < 1000 nM
Compound 4: a limit, no number; the forecaster's own chance of this, stated with the estimate: 5%; at least 16-fold (1.20 log units) between middle value and limit.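

In this assay, this aromatic carbon had carried pyridin-3-yl and 1,3,5-trimethyl-1H-pyrazol-4-yl with readable numbers, but keeping a six-membered aromatic ring with 1 hetero atom does not preserve the read-out: 5-aminopyridin-2-yl gives an at least 9.0-fold lower number from compound 3 to compound 4 (0.95 log units; beyond the scatter), and also an at least 35-fold lower number from compound 2 to compound 4 (1.54 log units; beyond the scatter). Both steps are known only as bounds, and the step between compound 1 and compound 4 cannot be read. The result for compound 4 is a limit of the assay and not a number, the same limit met with 1H-benzimidazol-2-yl in compound 1: the limit of < 1000 nM in this assay, at which 2 of the 4 values shown sit.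

Going by these compounds, the exchange changes both the amine and the point of attachment of the pyridine ring, so which of the two carries the step stays open. An unsubstituted pyridin-2-yl, or a pyridin-3-yl bearing an amine, would separate them.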